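The compounds below may be only part of what the source reports. "The series", "measured", "known", "first", "only" and "open" are said of these compounds alone.

Measured so far: compound 1 `CNC(=O)c1cc(Oc2ccc(NC(=O)c3nn(-c4ccccc4C(F)(F)F)c(=O)cc3C)cc2F)ccn1`, > 40000 nM; compound 2 `CNC(=O)c1cc(Oc2ccc(NC(=O)c3nn(-c4ccc(Br)cc4F)c(=O)cc3C)cc2F)ccn1`, 7930 nM; compound 3 `CNC(=O)c1cc(Oc2ccc(NC(=O)c3nn(-c4ccccc4F)c(=O)cc3C)cc2F)ccn1`, > 40000 nM.

In a functional assay on A549 cells (Homo sapiens) for cytotoxicity, read by MTT assay, with a stated time of 72 h (on this read-out lower numbers stand for stronger inhibition and higher numbers for weaker inhibition), compound 1 gives > 40000 nM, which is a limit of the assay and not a number. Compound 1 sits at the limit of > 40000 nM in this assay, at which 2 of the 3 values shown sit. The measured steps, an at least 5.0-fold lower number from compound 1 to compound 2 (0.70 log units; beyond the scatter), an at least 5.0-fold higher number from compound 2 to compound 3 (0.70 log units; beyond the scatter) and a step that the two limits leave unreadable from compound 1 to compound 3, all concern the aryl group on the aromatic nitrogen of the shared core.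

Compound 4 `Cc1cc(=O)n(-c2ccccc2C(F)(F)F)nc1C(=O)Nc1ccc(Oc2ncnc3sccc23)c(F)c1` differs from compound 1 at another place: a group of 9 heavy atoms (6 carbon, 2 nitrogen, 1 sulfur; one five-membered aromatic ring with 1 hetero atom, one six-membered aromatic ring with 2 hetero atoms) in place of a group of 10 heavy atoms (7 carbon, 2 nitrogen, 1 oxygen; one six-membered aromatic ring with 1 hetero atom), on an oxygen on an aromatic ring. Among the measured compounds shown here, none of the measured steps touches this oxygen-linked group, so they do not bear on the change, and with compound 1 at a limit no direction can be read. Compound 4 is therefore expected to give roughly 20000 nM, between 3000 nM and 40000 nM, a step of an at least 2.0-fold lower number from compound 1 to compound 4 (0.30 log units; that floor lies within the scatter) that is wholly uncertain.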

Compound 4, half-maximal inhibitory concentration: 16300 nM
Compound 4: middle estimate off by 1.2-fold (0.09 log units), on the high side, within the range that was stated.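

In this assay, the change on the oxygen on an aromatic ring gives an at least 2.4-fold lower number from compound 1 to compound 4 (0.38 log units; beyond the scatter), showing that this place also moves the read-out while the 2-(trifluoromethyl)phenyl group stays fixed. Compound 1 stands at a limit and not at a number, so the size of this step is only a floor: the limit of > 40000 nM in this assay, at which 2 of the 4 values shown sit.

The compounds shown leave open whether the same change would give a similar step with the 4-bromo-2-fluorophenyl group of compound 2. They also leave open how an amine or a carboxylic acid on the entering group would read.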